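Triazole aryl swap: chlorophenyl in place of trifluoromethylphenyl

The source may hold more compounds than are shown below. What is called first, only, known or untested is meant among the compounds shown, and "the series" means these compounds.

Three analogues of the shared core carry a substituted phenyl on the triazole nitrogen: compound 1 `C/C(=C\CC/C(C)=C/CC[C@@H]1[C@@]2(C)CCC(=O)C(C)(C)[C@H]2CC[C@@]1(C)O)CC/C=C(\C)C(=O)OCc1cn(-c2ccc(F)cc2)nn1`, compound 2 `C/C(=C\CC/C(C)=C/CC[C@@H]1[C@@]2(C)CCC(=O)C(C)(C)[C@H]2CC[C@@]1(C)O)CC/C=C(\C)C(=O)OCc1cn(-c2ccc(C(F)(F)F)cc2)nn1` and compound 3 `C/C(=C\CC/C(C)=C/CC[C@@H]1[C@@]2(C)CCC(=O)C(C)(C)[C@H]2CC[C@@]1(C)O)CC/C=C(\C)C(=O)OCc1cn(-c2cccc(Cl)c2)nn1`. In an ADME assay on L132 cells (Homo sapiens) for cytotoxicity, read by MTT assay, with a stated time of 48 h (on this read-out lower numbers stand for stronger inhibition and higher numbers for weaker inhibition), compound 2 gives only a limit, > 150000 nM. Compound 1 likewise reaches a limit in this assay, > 150000 nM; both rest on (the limit of > 150000 nM in this assay, at which 2 of the 3 values shown sit). Compound 3 gives a number in this assay, 94200 nM. Among the measured compounds shown here, the step that the two limits leave unreadable from compound 1 to compound 2 is not readable, whereas an at least 1.5-fold lower number from compound 2 to compound 3 (0.20 log units; that floor lies within the scatter) gives the only readable move from compound 2. Compound 4 `C/C(=C\CC/C(C)=C/CC[C@@H]1[C@@]2(C)CCC(=O)C(C)(C)[C@H]2CC[C@@]1(C)O)CC/C=C(\C)C(=O)OCc1cn(-c2ccccc2Cl)nn1` differs from compound 2 by 2-chlorophenyl in place of 4-(trifluoromethyl)phenyl on an aromatic nitrogen. Since the chlorophenyl in an at least 1.5-fold lower number from compound 2 to compound 3 (0.20 log units; that floor lies within the scatter) brought a number below the limit, the expected step is an at least 1.2-fold lower number from compound 2 to compound 4 (0.09 log units; that floor lies within the scatter), with a real chance of a limit again. Compound 4 is estimated at 120000 nM, between 60000 nM and 250000 nM.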

Compound 4, half-maximal inhibitory concentration: > 150000 nM
Compound 4: only a limit was reported (the forecaster's own chance of this, stated with the estimate: 45%); middle value at least 1.2-fold (0.09 log units) away from the limit.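

In this assay, 2-chlorophenyl in place of 3-chlorophenyl on the aromatic nitrogen gives an at least 1.5-fold higher number from compound 3 to compound 4 (0.20 log units; that floor lies within the scatter). A chlorophenyl group alone therefore does not ensure a readable number: compound 3 gives one, whereas the value of compound 4 is a limit. The steps to compound 4 from compound 1 and from compound 2 cannot be read, and most of the series now rests on one limit: the limit of > 150000 nM in this assay, at which 3 of the 4 values shown sit.

Going by these compounds, the order among compound 1, compound 2 and compound 4 remains open. Also open, on these data alone, is whether an amine or a carboxylic acid on the phenyl ring would give a readable number.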